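Pentyl on selenium and growth inhibition across two cores

This account rests on a few compounds, and the source may have more. Where it says the series, first, only, none or still open, it means among the compounds named here.

Of the compounds shown here, three have been measured in an ADME assay on 184B5 cells (Homo sapiens) for cytotoxicity, read by MTT assay, with a stated time of 72 h; a higher number here means a weaker inhibitor of growth, a lower number a stronger inhibitor of growth. Compound 1 `CCCCC[Se]c1nc(NCc2ccc(SC)cc2)c2ccccc2n1` gives 57400 nM. Compound 2 `CSc1ccc(CNc2nc([SeH])nc3ccccc23)cc1` gives 6840 nM in this assay. Compound 3 `Nc1nc([SeH])nc2ncccc12`, built on a different core, gives 5200 nM in this assay; the difference between the two cores is not broken down here. Compound 3 has the lowest number of the three, though its gap to compound 2 lies within the scatter, so no order is claimed between them.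

One structural change is seen twice among these compounds. Between compound 2 and compound 1 it is pentyl in place of hydrogen on a selenium, and it produced an 8.4-fold higher number from compound 2 to compound 1 (0.92 log units; beyond the scatter). Compound 4 `CCCCC[Se]c1nc(N)c2cccnc2n1`, not yet measured, differs from compound 3 by pentyl in place of hydrogen on a selenium; the place lines match word for word, so this is the same change.

Within the data shown here, compound 4 is expected to follow compound 3 by a 7.7-fold higher number from compound 3 to compound 4 (0.89 log units; beyond the scatter) in this assay, a step expected to resemble the one seen as an 8.4-fold higher number from compound 2 to compound 1 (0.92 log units; beyond the scatter), since that is the only precedent. Compound 4 is therefore estimated at 40000 nM, with a plausible range from 15000 nM to 120000 nM.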

Compound 4, concentration for 50% growth inhibition: 10300 nM
Estimate against measurement, compound 4: 3.9-fold (0.59 log units) above, and the stated range ends above it.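

In this assay, pentyl in place of hydrogen on a selenium gave a 2.0-fold higher number from compound 3 to compound 4 (0.30 log units; within the scatter), so on the core of compound 3 the change cannot be told apart from repeat measurement. Set beside the earlier step, the change did not carry over at the same size from one core to the other: the same change on two cores in this assay, an 8.4-fold higher number (0.92 log units; beyond the scatter) from compound 2 to compound 1 and a 2.0-fold higher number (0.30 log units; within the scatter) from compound 3 to compound 4, 4.2-fold (0.63 log units) apart, beyond the scatter of two such steps. Among these compounds, the step seen on the core of compound 2 therefore cannot be applied as a fixed increment, but with only one pair on each core, this does not show which feature of the cores separates the two steps or how the change would behave on a third core.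

Pentyl is the only group shown on selenium, so it remains open whether a shorter chain such as ethyl, a longer chain such as octyl or a benzyl group would also give steps that differ from core to core. Whether any such steps would keep the same direction on both cores is also left open.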